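The source may report more compounds than this note shows. Statements on the series, on what has been measured and on what is new or still open speak of the compounds shown alone.

Compound 3 `CCOC(=O)CCCCCOc1cccc(CN(C(=O)c2ccc(-c3cccc(OC)c3)cc2)C(C)C)c1` belongs to a small set of amides that share one core and differ only in the ring attached to it. In an ADME assay on BJ cells (Homo sapiens) for cytotoxicity, read by CellTiter-Glo and resazurin assay, with a stated time of 72 h (a higher number here means that more compound is needed for the effect, a lower number that less compound is needed), compound 3 gives > 21000 nM, which is a limit of the assay and not a number. Compound 1 `CCOC(=O)CCCCCOc1cccc(CN(C(=O)c2ccc(-c3cccnc3)cc2)C(C)C)c1` gives > 26000 nM, again a limit. Compound 2 `CCOC(=O)CCCCCOc1cccc(CN(C(=O)c2ccc(-c3cccc(OCC(C)C)c3)cc2)C(C)C)c1` gives > 26000 nM, also a limit. Because every value sits at the limit of > 26000 nM in this assay, at which 2 of the 3 values shown sit, or (the limit of > 21000 nM in this assay, at which 1 of the 3 values shown sits), the steps a step that the two limits leave unreadable from compound 1 to compound 2, a step that the two limits leave unreadable from compound 1 to compound 3 and a step that the two limits leave unreadable from compound 2 to compound 3 have no readable size. Compound 4 `CCOC(=O)CCCCCOc1cccc(CN(C(=O)c2ccc(-c3cccc(F)c3)cc2)C(C)C)c1` carries the change (fluoro in place of methoxy on an aromatic carbon). For the measured compounds named here, no measured step bears on it, so no direction can be read; compound 4 is expected to stay at a limit as well, with an estimated step that the limit leaves unreadable from compound 3 to compound 4 and an estimated value of 26000 nM (12000 nM to 60000 nM).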

Compound 4, half-maximal effective concentration: > 26000 nM
Compound 4 ended at the assay's limit; the forecaster's own chance of this, stated with the estimate: 85%; the middle value sits exactly at the limit.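

For the compounds shown here, compound 4 also sits at a limit in this assay, as do compound 1, compound 2 and compound 3, so no step between compound 4 and any of them can be read. The compounds shown leave open what concentration each one needs for the effect, and whether changing the group on the ring alters it at all.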